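The source may report more compounds than this note shows. Statements on the series, on what has been measured and on what is new or still open speak of the compounds shown alone.

Working notes on the series. Among the compounds with values here, in a functional assay for inhibition, with Rattus norvegicus as the target (on this read-out lower numbers stand for stronger inhibition and higher numbers for weaker inhibition), compound 1 (`CCc1c(CC)c(OC(C)=O)c2c(C)c(C)cc(C)c2c1OC`) gives 15700 nM and compound 2 (`CCc1c(CC)c(OC(C)=O)c2c(C)ccc(C)c2c1OC`) gives 13000 nM so compound 1 stands within the scatter of the only other measured member. The next member is compound 3 (`CCc1c(CC)c(OC(C)=O)c2c(C)c(C)c(C)c(C)c2c1OC`), and its difference from compound 1 is methyl in place of hydrogen on an aromatic carbon in the form of methyl in place of hydrogen on an aromatic carbon, ortho to two methyl groups. Within the data shown here, only one measured step bears on this: a 1.2-fold lower number from compound 1 to compound 2 (0.08 log units; within the scatter) for the reverse kind of change, hydrogen in place of methyl on an aromatic carbon. One step is thin evidence. Because a 1.2-fold lower number from compound 1 to compound 2 (0.08 log units; within the scatter) is so small, no shift beyond the scatter is expected in this assay and the expected size is a 1.0-fold higher number from compound 1 to compound 3 (0.01 log units; within the scatter) in either direction. For compound 3 the estimate is 16000 nM with 7500 nM to 33000 nM as the expected range.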

Compound 3, half-maximal inhibitory concentration: 37300 nM
Compound 3: middle estimate off by 2.3-fold (0.37 log units), on the low side, and the stated range ends below it.
By their numbers in this assay, from the lowest: compounds 2 and 1 (each within the scatter of the next); then compound 3.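

In this assay, within the data shown here, methyl in place of hydrogen on this aromatic carbon, ortho to two methyl groups, gives the first step beyond the scatter: a 2.4-fold higher number from compound 1 to compound 3 (0.38 log units; beyond the scatter), a modest move towards weaker inhibition. The earlier step, a 1.2-fold lower number from compound 1 to compound 2 (0.08 log units; within the scatter), concerns a methyl on another aromatic carbon and stays within the scatter, so a methyl change on this ring is not silent at every carbon. Nothing at hand accounts for the shift at this position.

Whether the shift belongs to methyl alone stays open, since the compounds shown carry only hydrogen or methyl here, and an ethyl, a methoxy, an amine or a carboxylic acid on this carbon could give a different number. Also open, on these data alone, is whether methyl here gives the same step when hydrogen replaces either of the two neighbouring methyl groups.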